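Working notes: a second benzyl, from compound 3 to compound 4

The compounds below may be only part of what the source reports. "The series", "measured", "known", "first", "only" and "open" are said of these compounds alone.

Compound 1 `COc1cc(OC)n2cc(-c3ccc([N+](=O)[O-])cc3)nc2n1` gives 70600 nM in a functional assay on LoVo cells (Homo sapiens) for antiproliferative activity, read by MTT assay, with a stated time of 72 h; on this read-out lower numbers stand for stronger inhibition of growth and higher numbers for weaker inhibition of growth. Compound 2 `CNc1ccc(-c2cn3c(OC)cc(OC)nc3n2)cc1` is reported only as a limit in this assay, namely > 100000 nM. Compound 3 `COc1cc(OC)n2cc(-c3ccc(NCc4ccccc4)cc3)nc2n1` also stands only at a limit in this assay, > 100000 nM, so the shared floor is the limit of > 100000 nM in this assay, at which 2 of the 3 values shown sit. Compound 4 `COc1cc(OC)n2cc(-c3ccc(N(Cc4ccccc4)Cc4ccccc4)cc3)nc2n1` differs from compound 3 by benzyl in place of hydrogen on a nitrogen on an aromatic ring. Among the compounds with values here, the steps that bear on this are an at least 1.4-fold higher number from compound 1 to compound 2 (0.15 log units; that floor lies within the scatter) and an at least 1.4-fold higher number from compound 1 to compound 3 (0.15 log units; that floor lies within the scatter), while a step that the two limits leave unreadable from compound 2 to compound 3. Neither amine variant yields a number, and no size or direction can be read for a benzyl on this nitrogen. The expected step is a number no higher from compound 3 to compound 4 (the limit leaves the size open), nothing beyond the scatter. Compound 4 is estimated at 100000 nM, between 30000 nM and 300000 nM, most probably reported again only as a limit.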

Compound 4, concentration for 50% growth inhibition: 61900 nM
Compound 4: middle estimate off by 1.6-fold (0.21 log units), on the high side; measured number inside the range.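

In this assay, within the data shown here, benzyl in place of hydrogen on this nitrogen gives the first amine variant with a measured number rather than a limit, a change the earlier compounds did not show: an at least 1.6-fold lower number from compound 3 to compound 4 (0.20 log units; that floor lies within the scatter). That step is only a floor within the scatter, so no real gain in growth inhibition can be claimed. Its true size stays unknown, since compound 3 is one of the compounds held at a limit: the limit of > 100000 nM in this assay, at which 2 of the 4 values shown sit.

The step from compound 2 to compound 3 cannot be read. Open too, from the compounds shown here alone, is whether a longer chain such as phenethyl, or a carboxylic acid on the benzyl ring, would give a number clearly beyond the scatter.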